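The source may hold more compounds than are shown below. What is called first, only, known or untested is meant among the compounds shown, and "the series" means these compounds.

Measured so far in an assay on K562 cells for displacement of a labelled ligand from Equilibrative nucleoside transporter 1 (Homo sapiens); a higher number here means a weaker inhibitor, a lower number a stronger inhibitor:
compound 1 `OC[C@H]1O[C@@H](n2cnc3c(SCc4ccccc4Cl)ncnc32)[C@H](O)[C@@H]1O`: 99.5 nM
compound 2 `OC[C@H]1O[C@@H](n2cnc3c(SCc4ccc(Cl)cc4)ncnc32)[C@H](O)[C@@H]1O`: 14.2 nM

For the measured compounds named here, compound 2 has the lowest number of the two; its only neighbour is compound 1, separated from it by the step of a 7.0-fold lower number from compound 1 to compound 2 (0.85 log units; beyond the scatter). Compound 3 `OC[C@H]1O[C@@H](n2cnc3c(SCc4ccccc4I)ncnc32)[C@H](O)[C@@H]1O` has not yet been measured. It differs from compound 2 by 2-iodophenyl in place of 4-chlorophenyl on a saturated chain carbon bound to a sulfur. Two things change at once: the halogen goes from the 4-chlorophenyl arrangement of compound 2 back to the 2-chlorophenyl arrangement seen in compound 1, and chlorine is exchanged for iodine. Going by the values given here, only one measured step bears on this, a 7.0-fold lower number from compound 1 to compound 2 (0.85 log units; beyond the scatter); read in reverse it points to a higher number for compound 3 of roughly that size. Among the compounds with values here, no measured pair shows what iodine does in place of chlorine, so the range is kept wide. Compound 3 is therefore expected to give 70 nM in this assay, within 20 nM to 250 nM, a step of a 4.9-fold higher number from compound 2 to compound 3 (0.69 log units; beyond the scatter).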

Compound 3, inhibition constant: 16.1 nM
Compound 3: middle estimate off by 4.3-fold (0.64 log units), on the high side; the whole stated range lies above it.
By their numbers in this assay, from the lowest: compounds 2 and 3 (each within the scatter of the next); then compound 1.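

In this assay, iodo in place of chloro on an aromatic carbon gives a 6.2-fold lower number from compound 1 to compound 3 (0.79 log units; beyond the scatter), so at this place on the benzyl group the identity of the halogen counts, and the weak reading of compound 1 does not hold for every 2-halophenyl group. 2-Iodophenyl and 4-chlorophenyl on the saturated chain carbon bound to a sulfur cannot be told apart here, with a 1.1-fold higher number from compound 2 to compound 3 (0.05 log units; within the scatter). No supporting evidence accounts for this result.

Still open, from the compounds shown here alone, is whether 4-iodophenyl would match 4-chlorophenyl, and so whether iodo in place of chloro has the same consequence in the 4-substituted arrangement. Also open, going by these compounds, is where 2-bromophenyl would fall relative to 2-chlorophenyl and 2-iodophenyl, and whether a non-halogen group such as methoxy or a carboxylic acid would be tolerated on this ring.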